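From 4-chlorophenyl to 3,4-difluorophenyl in compound 4

The source may report more compounds than this note shows. Statements on the series, on what has been measured and on what is new or still open speak of the compounds shown alone.

Compound 1 `COc1ccc(-c2nc3ccccc3o2)cc1NC(=O)c1cc([N+](=O)[O-])ccc1Cl`: > 25000 nM
Compound 2 `O=C(Nc1ccc(-c2nc3ccccc3s2)cc1)c1cc([N+](=O)[O-])ccc1Cl`: > 27000 nM
Compound 3 `O=C(Nc1nc(-c2ccc(Cl)cc2)cs1)c1cc([N+](=O)[O-])ccc1Cl`: > 27000 nM

All three compounds were tested in an ADME assay on HepG2 cells (Homo sapiens) for cytotoxicity, with a stated time of 72 h (a higher number here means that more compound is needed for the effect, a lower number that less compound is needed), and each result is a limit of the assay, not a number. Compound 3 stands at the limit of > 27000 nM in this assay, at which 2 of the 3 values shown sit. It shares that limit with compound 2, while compound 1 has a limit of its own, so no measured number exists against which compound 3 could be placed.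

Compound 4 `O=C(Nc1nc(-c2ccc(F)c(F)c2)cs1)c1cc([N+](=O)[O-])ccc1Cl` has not yet been measured. It carries 3,4-difluorophenyl in place of the 4-chlorophenyl of compound 3, on an aromatic carbon of a five-membered aromatic ring with 1 nitrogen and 1 sulfur, next to the ring nitrogen: 3,4-difluorophenyl in place of 4-chlorophenyl on an aromatic carbon. The rest of the structure stays the same.

Going by the values given here, no two measured compounds differ in one place only, so the series offers no measured step to go by. No change beyond the usual scatter is expected in this assay, in either direction. That expectation rests on compound 3, whose > 27000 nM is a limit. The estimated step is a number no higher from compound 3 to compound 4 (the limit leaves the size open). Compound 4 is estimated at 27000 nM, with an expected range from 12000 nM to 55000 nM.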

Compound 4, half-maximal effective concentration: > 27000 nM
Compound 4: a limit, no number; the forecaster's own chance of this, stated with the estimate: 75%; the middle value lies on the limit itself.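

In this assay compound 4 gives > 27000 nM, a limit of the assay and not a number. Compound 3 likewise has only a limit, so no step can be read between compound 3 and compound 4. The compounds shown leave open what 3,4-difluorophenyl in place of 4-chlorophenyl does to the half-maximal effective concentration in this assay.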